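A few compounds are considered here, and "the series" means these few. Any claim that something is new, unique, unknown or untested is made for them only; others in the source may bear on it.

Working notes on the series. In a functional assay on RAW264.7 cells (Mus musculus) for inhibition, read by Griess assay, with stated times of 3 h and 24 h (a higher number here means a weaker inhibitor, a lower number a stronger inhibitor), compound 1 (`C=C1CCC2[C@](C)(CO)[C@H](O)CC[C@@]2(C)[C@@H]1CCn1ccnc1`) stands at > 50000 nM as a limit and not a number. Compound 2 (`C=C1CCC2[C@](C)(CO)[C@H](O)CC[C@@]2(C)[C@@H]1CCOc1ccc(-c2cc(=O)c3cc(C)ccc3o2)cc1`) gives > 100000 nM as a limit too. Among the measured compounds shown here, these two limits are the only readings so far, so no measured step is available and no order can be set between the two compounds.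

The next compound to be read is compound 3 (`C=C1CCC2[C@](C)(CO)[C@H](O)CC[C@@]2(C)[C@@H]1CCOC(=O)c1cccnc1`), which carries ((pyridin-3-yl)carbonyl)oxy in place of 1H-imidazol-1-yl on a saturated chain carbon, two bonds along the chain from a saturated ring carbon.

In this assay the expected step of an at least 1.2-fold lower number from compound 1 to compound 3 (0.09 log units; that floor lies within the scatter) is none beyond the scatter, and no direction is favoured. The estimated value for compound 3 is 40000 nM (expected range 10000 nM to 100000 nM) and another limit would be no surprise.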

Compound 3, half-maximal inhibitory concentration: > 50000 nM
Compound 3 gave a limit, no number; the forecaster's own chance of this, stated with the estimate: 60%; middle value at least 1.2-fold (0.09 log units) from the limit.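

Compound 1 and compound 3 both read as limits in this assay, so the step between them cannot be read. The compounds shown leave open what number either would give, and whether 1H-imidazol-1-yl or ((pyridin-3-yl)carbonyl)oxy at this place makes any difference.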